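The source may report more compounds than this note shows. Statements on the series, on what has been measured and on what is new or still open speak of the compounds shown alone.

Of the compounds shown here, three with a shared core have been measured in a functional assay (B cells) with Mus musculus as the target; on this read-out lower numbers stand for an effect already at smaller amounts and higher numbers for an effect only at larger amounts of compound. Compound 1, `C=CCn1c(=O)n(CCC(CCOCc2ccccc2)CCOCc2ccccc2)c2nc(N)nc(O)c21`, gives 7 uM in this assay. Compound 3, `C=CCn1c(=O)n([C@@H]2O[C@H](CO)[C@H]3OC(=O)O[C@H]32)c2nc(N)nc(O)c21`, gives 3 uM. Compound 2, `Nc1nc(O)c2c(n1)n(C1OC(CO)[C@@H](O)[C@H]1O)c(=O)n2CC(O)CSc1ccccc1`, gives 142 uM, the highest of the three numbers: its nearest neighbour is compound 1, whose number is lower by a gap beyond the scatter, and the furthest is compound 3, whose number is lower still, also beyond the scatter. Within the data shown here, compound 1 and compound 3 each carry an allyl on the ring nitrogen where compound 2 carries the larger substituent, though no single-point step connects them to compound 2.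

Compound 4, `CCn1c(=O)n(C2OC(CO)[C@@H](O)[C@H]2O)c2nc(N)nc(O)c21`, has not yet been measured. It differs from compound 2 in one place: methyl in place of 1-hydroxy-2-(phenylsulfanyl)ethyl on a saturated chain carbon bound to an aromatic nitrogen. Since both compounds with a small group on that nitrogen, compound 1 at 7 uM and compound 3 at 3 uM, give lower numbers than compound 2 at 142 uM, a step toward a lower number is expected for this change, of moderate size and beyond the scatter. The expected step from compound 2 to compound 4 is a 9.5-fold lower number from compound 2 to compound 4 (0.98 log units; beyond the scatter). Compound 4 is therefore estimated to give about 15 uM in this assay, with a range from 3 uM to 70 uM.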

Compound 4, concentration for half-maximal effect: 15 uM
Compound 4: the middle estimate sits on the measured number at the digits printed; measured number inside the range.
By their numbers in this assay, from the lowest: compound 3; then compound 1; then compound 4; then compound 2.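

In this assay, among these compounds, putting methyl in place of 1-hydroxy-2-(phenylsulfanyl)ethyl on a saturated chain carbon bound to an aromatic nitrogen gives a 9.5-fold lower number from compound 2 to compound 4 (0.98 log units; beyond the scatter), the first step at this position that can be read with the rest of the structure unchanged. The pair shows that the six-membered aromatic ring and the hydroxy group of the leaving substituent are not needed for an effect in this assay, since the number falls beyond the scatter once both are gone. No measurement shown here accounts for the size of this step.

A single step removes the hydroxy group, the sulfur and the aromatic ring together, so the compounds shown leave open what each contributes, and whether a hydrogen in place of the methyl, a longer chain such as propyl, or an amine on the chain would lower the number further. Among the compounds shown here, compound 1 and compound 3 differ from compound 4 in more than one place, so no steps from them to compound 4 can be read, and the effect of the allyl group at this position on the shared core also stays open.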